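A few compounds are considered here, and "the series" means these few. Any claim that something is new, unique, unknown or untested is made for them only; others in the source may bear on it.

In a functional assay on OVCAR-3 cells (Homo sapiens) for antiproliferative activity, read by MTT assay, with a stated time of 24 h (a lower number here means a stronger inhibitor, a higher number a weaker inhibitor), compound 1 (`Cc1ccccc1NNC(=O)c1ccc(NS(=O)(=O)c2cnc(O)nc2O)cc1`) gives > 20000 nM, which is a limit of the assay and not a number. Compound 3 (`Cc1ccccc1NNC(=O)c1cccc(NS(=O)(=O)c2cnc(O)nc2O)c1`) gives > 20000 nM, which is also a limit. Compound 3 therefore stands at the limit of > 20000 nM in this assay, at which 2 of the 3 values shown sit. Compound 2 (`O=C(NNc1ccccc1Cl)c1ccc(NS(=O)(=O)c2cnc(O)nc2O)cc1`) gives a true number, 7230 nM.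

Compound 4 (`O=C(NNc1cccc(Cl)c1)c1cccc(NS(=O)(=O)c2cnc(O)nc2O)c1`) differs from compound 3 by having 3-chlorophenyl in place of 2-methylphenyl on an amine nitrogen.

Going by the values given here, only one measured step bears on this change, an at least 2.7-fold lower number from compound 1 to compound 2 (0.44 log units; beyond the scatter), where chloro replaces methyl on an aromatic carbon. It suggests that trading the methyl for a chlorine can move a compound off the limit and toward stronger inhibition. The match is only partial, however, since the group entering compound 4 is 3-chlorophenyl, and one step is thin support for any rule. A move in the same direction and of modest size is therefore expected in this assay, and another reading that gives only a limit remains possible. The expected change is an at least 2.0-fold lower number from compound 3 to compound 4 (0.30 log units; that floor lies within the scatter). For compound 4 the estimated value is 10000 nM, with an expected range from 4000 nM to 20000 nM.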

Compound 4, half-maximal inhibitory concentration: 8040 nM
For compound 4 the middle estimate is 1.2-fold (0.09 log units) above the measured one; low and high end bracket the measured number.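

Swapping 2-methylphenyl for 3-chlorophenyl on the amine nitrogen gives an at least 2.4-fold lower number from compound 3 to compound 4 (0.39 log units; beyond the scatter) in this assay, so this position can take a change that yields a true number instead of a limit. Until now, a gain on replacing methyl with chloro had been seen only in the step from compound 1 to compound 2; the new step shows a gain of the same direction on the core of compound 3, with the chlorine carried as 3-chlorophenyl, and neither pair shown goes against it. Compound 3 itself is only a limit, so the step is a floor and its true size remains unknown: the limit of > 20000 nM in this assay, at which 2 of the 4 values shown sit.

This single change replaces the methyl with a chlorine and also alters where the group sits on the ring, so the compounds shown cannot tell which of the two accounts for the step. A 3-methylphenyl group on the same nitrogen would separate these two changes, while an unsubstituted phenyl, 3-fluorophenyl or 3-bromophenyl group would show whether a halogen is needed at all and whether chlorine is the best one.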